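From Isopropyl Amide to Isopropyl Urea on a Shared Core

A few compounds are considered here, and "the series" means these few. Any claim that something is new, unique, unknown or untested is made for them only; others in the source may bear on it.

Compound 3 `COC(=O)/C=C/c1cccc(N(Cc2ccc(-c3ccc(C)cc3)cc2)C(=O)C(C)C)c1` gives 118 nM in an assay on isolated protein with Bile acid receptor (Homo sapiens) as the target; a lower number here means that less compound is needed, a higher number that more compound is needed for the effect. Among the three measured compounds it has the lowest number: compound 2 `COC(=O)/C=C/c1cccc(N(Cc2ccc(/C=C/c3ccc(F)cc3)cc2)C(=O)NC(C)C)c1` gives 348 nM, and compound 1 `COC(=O)/C=C/c1cccc(N(Cc2ccc(/C=C/c3cccc(C(F)(F)F)c3)cc2)C(=O)NC(C)C)c1` gives 932 nM, both beyond the scatter from compound 3. Among the compounds with values here, the only step between measured compounds that differ in one place is a 2.7-fold lower number from compound 1 to compound 2 (0.43 log units; beyond the scatter), a change on the double-bonded chain that neither compound 3 nor compound 4 carries.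

Compound 4 `COC(=O)/C=C/c1cccc(N(Cc2ccc(-c3ccc(C)cc3)cc2)C(=O)NC(C)C)c1` differs from compound 3 in one place: isopropylamino in place of isopropyl on a carbonyl carbon. Within the data shown here, no measured pair isolates this change. Compounds 1 and 2 already carry the isopropylamino group, but they differ from compound 3 in the other part of the molecule as well, so their values cannot be set against compound 3 to read off what this exchange does. With nothing to lean on, the expected step of a 1.1-fold higher number from compound 3 to compound 4 (0.04 log units; within the scatter) is placed within the scatter, with a wide range allowed in either direction. Compound 4 is therefore expected to give 130 nM in this assay, with the estimate spanning from 45 nM to 400 nM.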

Compound 4, half-maximal effective concentration: 449 nM
Beside the measured number, compound 4's estimate is 3.5-fold (0.54 log units) below it, outside the stated range (above it).
By their numbers in this assay, from the lowest: compound 3; then compounds 2 and 4 (each within the scatter of the next); then compound 1.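

Read directly for the first time, the exchange of isopropyl for isopropylamino on the carbonyl carbon raises the number in this assay (a 3.8-fold higher number from compound 3 to compound 4 (0.58 log units; beyond the scatter)), and on this core the exchange brings in one nitrogen and one hydrogen-bond donor. The low number of compound 3 therefore does not come with the 4-methylphenyl group alone, since compound 4 carries that same group and loses the advantage once isopropylamino stands on the carbonyl carbon. With isopropylamino held in place, the other end of the molecule can now be read as well: 4-methylphenyl in place of 2-(4-fluorophenyl)ethenyl leaves the number within the scatter (a 1.3-fold higher number from compound 2 to compound 4 (0.11 log units; within the scatter)), whereas 4-methylphenyl in place of 2-(3-(trifluoromethyl)phenyl)ethenyl gives a step beyond it (a 2.1-fold lower number from compound 1 to compound 4 (0.32 log units; beyond the scatter)).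

Still open, from the compounds shown here alone, is whether dimethylamino on the carbonyl carbon, which keeps the nitrogen and has no hydrogen on it, would fall with compound 3 or with compound 4, and whether a cyclopropyl or tert-butyl group there would match isopropyl. Nothing at hand explains why the exchange raises the number.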